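Compound 4 Before the Number: What the Three Measured Analogues Say

The compounds below may be only part of what the source reports. "The series", "measured", "known", "first", "only" and "open" are said of these compounds alone.

Three compounds have been measured in a functional assay on MCF7 cells (Homo sapiens) for antiproliferative activity, read by CCK-8 assay, with a stated time of 48 h; on this read-out higher numbers stand for weaker inhibition and lower numbers for stronger inhibition:

- compound 1, `O=c1c2ccccc2[se]n1-c1nnc(-c2ccc(Br)cc2)s1`, giving 43300 nM
- compound 2, `O=c1c2ccccc2[se]n1-c1nnc(-c2cc([N+](=O)[O-])cc([N+](=O)[O-])c2)s1`, giving 37800 nM
- compound 3, `COc1ccc(-c2nnc(-n3[se]c4ccccc4c3=O)s2)cc1`, giving 10000 nM

Among these, compound 1 holds the highest number of the three; compound 2 is nearest to it, within the scatter, and compound 3 is furthest, beyond it. Among the compounds with values here, the one step measured from compound 1 is a 4.3-fold lower number from compound 1 to compound 3 (0.64 log units; beyond the scatter), a modest shift that comes with methoxy in place of bromo on an aromatic carbon.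

Compound 4, `Cc1ccccc1-c1nnc(-n2[se]c3ccccc3c2=O)s1`, has not yet been measured. It differs from compound 1 as follows: 2-methylphenyl in place of 4-bromophenyl on an aromatic carbon. Within the data shown here, no measured pair shows this exact exchange, so the only comparison available is the bromo-to-methoxy step from compound 1 to compound 3, which moved the number by a modest amount. With 2-methylphenyl in place of 4-bromophenyl on an aromatic carbon, the expectation for compound 4 in this assay is a step of a 1.4-fold lower number from compound 1 to compound 4 (0.16 log units; within the scatter), that is, a number near compound 1 and not clearly beyond the scatter in either direction. The estimate for compound 4 is therefore 30000 nM, with a range from 10000 nM to 80000 nM, the measurement itself still to come.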

Compound 4, half-maximal inhibitory concentration: 36800 nM
Compound 4: middle estimate off by 1.2-fold (0.09 log units), on the low side, within the range that was stated.
By their numbers in this assay, from the lowest: compound 3; then compounds 4, 2 and 1 (each within the scatter of the next).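

In this assay, 2-methylphenyl in place of 4-bromophenyl, on the aromatic carbon next to the ring nitrogen and next to the ring sulfur, gives a 1.2-fold lower number from compound 1 to compound 4 (0.07 log units; within the scatter) and so stays within the scatter, even though the whole aryl group is exchanged. Set beside a 4.3-fold lower number from compound 1 to compound 3 (0.64 log units; beyond the scatter), which lies beyond the scatter, this shows that not every exchange at this position shifts the number: the methoxy-bearing ring of compound 3 does, whereas the 2-methylphenyl of compound 4 does not. Nothing available bears on the reason these two exchanges part ways, so the result stands here without an explanation.

Compound 4 differs from compound 1 both in the group carried on the phenyl ring and in where that group sits, so the compounds shown cannot separate these two changes. Going by these compounds, it also remains open whether a hydroxyl, an amine or a carboxylic acid on the phenyl ring, or a longer chain such as ethoxy in place of the methoxy of compound 3, would move the number as far as the methoxy exchange did, or further.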